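A Nitrophenyl Gives Way to a Cyanophenyl

The source may report more compounds than this note shows. Statements on the series, on what has been measured and on what is new or still open speak of the compounds shown alone.

Two compounds share one core and differ only in the aromatic group carried on a saturated chain carbon bound to an aromatic nitrogen. Compound 1, `O=c1ccoc2cc(OCc3cn(Cc4ccccc4Cl)nn3)ccc12`, carries a 2-chlorophenyl there. In an ADME assay on L02 cells (Homo sapiens) for cytotoxicity, read by MTT assay, with a stated time of 48 h (a higher number here means a weaker inhibitor, a lower number a stronger inhibitor), compound 1 gives a limit of the assay rather than a number, > 300000 nM. Compound 2, `O=c1ccoc2cc(OCc3cn(Cc4ccc([N+](=O)[O-])cc4)nn3)ccc12`, carries a 4-nitrophenyl in the same place. In this assay compound 2 likewise gives only a limit, > 300000 nM. The step between them, a step that the two limits leave unreadable from compound 1 to compound 2, cannot be sized, since both values are limits. Within the data shown here, compound 2 therefore stands at the ceiling of what was measured, and so does its only neighbour, as the limit of > 300000 nM in this assay, at which 2 of the 2 values shown sit, states.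

Compound 3, `N#Cc1cccc(Cn2cc(COc3ccc4c(=O)ccoc4c3)nn2)c1`, makes one change: 3-cyanophenyl in place of 4-nitrophenyl on a saturated chain carbon bound to an aromatic nitrogen. Among the measured compounds shown here, the only measured step bearing on this place is the unreadable one from compound 1 to compound 2, so no direction or size can be drawn from it. Compound 3 is expected to sit at the same limit, a step that the limit leaves unreadable from compound 2 to compound 3. The estimate for compound 3 in this assay is 350000 nM, within 120000 nM to 1000000 nM.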

Compound 3, half-maximal inhibitory concentration: > 300000 nM
Compound 3 ended at the assay's limit; the forecaster's own chance of this, stated with the estimate: 85%; the middle value is on the limit's open side.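

In this assay compound 3 gives > 300000 nM as a limit of the assay and not a number. Among these compounds, no step among compound 1, compound 2 and compound 3 can be read, since all three stop at the same ceiling: the limit of > 300000 nM in this assay, at which 3 of the 3 values shown sit.

The compounds shown leave open whether these three aromatic groups differ at all in this assay, and what change in this place would bring a value within its range.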